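Notes on the step from compound 3 to compound 4

A few compounds are considered here, and "the series" means these few. Any claim that something is new, unique, unknown or untested is made for them only; others in the source may bear on it.

Measured in a toxicity assay on MT4 cells (Homo sapiens) for cytotoxicity, read by MTT assay; a lower number here means that less compound is tolerated, a higher number that more compound is tolerated
- compound 1 `Cc1cc(-c2ccc(C#N)c(C#N)c2)ccc1Oc1cc(N)nc(Nc2ccc(C#N)cc2)n1` gives 76700 nM
- compound 2 `COc1cc(Oc2cc(N)nc(Nc3ccc(C#N)cc3)n2)ccc1-c1ccc(C#N)cc1` gives 12900 nM
- compound 3 `Cc1cc(-c2ccccc2Cl)cc(C)c1Oc1cc(N)nc(Nc2ccc(C#N)cc2)n1` gives 25100 nM

In this assay compound 3 (25100 nM) lies within the scatter of compound 2 (12900 nM). Compound 1 (76700 nM) gives the highest number of the three, beyond the scatter of both.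

Compound 4 `COc1ccccc1-c1cc(C)c(Oc2cc(N)nc(Nc3ccc(C#N)cc3)n2)c(C)c1` is not yet measured. It carries methoxy in place of chloro on an aromatic carbon, ortho to a large group, so 2-chlorophenyl becomes 2-methoxyphenyl (methoxy in place of chloro on an aromatic carbon).

Among the measured compounds shown here, no measured pair isolates a change of this kind, so the data give no direct guide to its size or direction. The expectation therefore stays close to compound 3 (25100 nM), with no step beyond the scatter. The expected change is small (a 1.2-fold lower number from compound 3 to compound 4 (0.08 log units; within the scatter)). The estimated value for compound 4 is 21000 nM (expected range 8000 nM to 60000 nM).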

Compound 4, half-maximal cytotoxic concentration: 21800 nM
Compound 4: middle estimate off by 1.0-fold (0.02 log units), on the low side, within the range that was stated.
By their numbers in this assay, from the lowest: compounds 2, 4 and 3 (each within the scatter of the next); then compound 1.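

In this assay, methoxy in place of chloro on an aromatic carbon, ortho to a large group, gives a 1.2-fold lower number from compound 3 to compound 4 (0.06 log units; within the scatter). This is the only pair shown that differs in one place, and it gives the series its first direct reading at this position: 2-chlorophenyl and 2-methoxyphenyl cannot be told apart here, even though methoxy brings an oxygen that chloro lacks. No measurement at hand speaks to the reason for this.

Going by these compounds, it remains open whether a group of another kind at this position, such as an amine or a carboxylic acid, would also stay within the scatter of compound 3. Also open, on these data alone, is whether methoxy in place of chloro would read the same at other places on this ring.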